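Swapping the anilide ring substituents on a shared core

The source may hold more compounds than are shown below. What is called first, only, known or untested is meant among the compounds shown, and "the series" means these compounds.

Of the compounds shown here, three built on the same core have been measured. Compound 1 `O=C(CN1CCC(c2cccc[n+]2[O-])CC1)Nc1cccc(F)c1` gives 160 nM in a functional assay on HEK293 cells for agonist activity at D(4) dopamine receptor (Homo sapiens), read by FLIPR (a lower number here means that less compound is needed, a higher number that more compound is needed for the effect), the lowest of the three numbers. Among the compounds with values here, compound 2 `CC(C)Oc1cccc(NC(=O)CN2CCC(c3cccc[n+]3[O-])CC2)c1` gives 555 nM, and the single change of isopropoxy in place of fluoro on an aromatic carbon accounts for a 3.5-fold higher number from compound 1 to compound 2 (0.54 log units; beyond the scatter). Compound 3 `Cc1ccc(Cl)c(NC(=O)CN2CCC(c3cccc[n+]3[O-])CC2)c1Cl` gives 346 nM; it differs from compound 1 in more than one place, so only the two values themselves can be compared, and its number is higher than that of compound 1.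

Compound 4 `Cc1cc(Br)ccc1NC(=O)CN1CCC(c2cccc[n+]2[O-])CC1` has not yet been measured. It differs from compound 1 by 4-bromo-2-methylphenyl in place of 3-fluorophenyl on an amide-type nitrogen. Within the data shown here, the only single-place step known on this ring, from compound 1 to compound 2, raised the number modestly, and compound 3, which also carries a methyl and halogen pattern on the same ring, sits above compound 1. A modest rise is therefore expected for compound 4, as a 1.9-fold higher number from compound 1 to compound 4 (0.27 log units; within the scatter). Compound 4 is estimated at 300 nM, within a range from 120 nM to 750 nM.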

Compound 4, half-maximal effective concentration: 66 nM
Estimate against measurement, compound 4: 4.5-fold (0.66 log units) above, and the stated range ends above it.
By their numbers in this assay, from the lowest: compound 4; then compound 1; then compounds 3 and 2 (each within the scatter of the next).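

In this assay, the ring on the amide-type nitrogen can also lower the number: 4-bromo-2-methylphenyl in place of 3-fluorophenyl gives a 2.4-fold lower number from compound 1 to compound 4 (0.38 log units; beyond the scatter). The earlier step on this ring, a 3.5-fold higher number from compound 1 to compound 2 (0.54 log units; beyond the scatter), went upward, so changes at this one place can move the number in either direction, and compound 1 no longer marks the low end of the series. Nothing measured here explains the drop seen with compound 4.

On these data alone, the new ring brings in a bromine and a methyl together, so the share of each remains open, as does whether either one alone would give the same result. Also open, as far as these compounds go, is how this ring would behave with a different kind of group on it, such as an amine or a carboxylic acid.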